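This account rests on a few compounds, and the source may have more. Where it says the series, first, only, none or still open, it means among the compounds named here.

Compound 1 `CC[C@@H]1C(=O)N(C)c2cnc(Nc3ccc(C(=O)NC4CCN(C)CC4)cc3OC)nc2N1C1CCCCC1` and compound 2 `CC[C@@H]1C(=O)N(C)c2cnc(Nc3ccc(C(=O)NC4CCN(C)CC4)cc3OC)nc2N1C(C)C` share a core and differ only at the nitrogen bearing the cyclohexyl or isopropyl group. In an assay on isolated protein for inhibition of serine/threonine-protein kinase PLK1 (Homo sapiens), read by Z'-LYTE (a higher number here means a weaker inhibitor, a lower number a stronger inhibitor), compound 1 gives 4 nM, and in this assay compound 2 gives 4 nM; the step of no change at the digits printed from compound 1 to compound 2 (within the scatter) shows that exchange left the read-out where it was, so compound 2 stands level with compound 1 on these numbers. Compound 3 `CC[C@@H]1C(=O)Nc2cnc(Nc3ccc(C(=O)NC4CCN(C)CC4)cc3OC)nc2N1C(C)C` is formed from compound 2 by hydrogen in place of methyl on an amide-type nitrogen in a ring. Among the measured compounds shown here, no measured step touches this position; the one step known, from compound 1 to compound 2, concerns a different nitrogen and was flat. For the measured compounds named here, the expectation therefore rests on no direct precedent, and compound 3 is estimated at 10 nM, with a range from 3 nM to 40 nM, implying a step of a 2.5-fold higher number from compound 2 to compound 3 (0.40 log units; beyond the scatter) that is expected to be modest and is judged uncertain.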

Compound 3, half-maximal inhibitory concentration: 2620 nM
The estimate for compound 3 lay 260-fold (2.42 log units) below the measured number; the whole stated range lies below it.
By their numbers in this assay, from the lowest: compounds 1 and 2 (each within the scatter of the next); then compound 3.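

The methyl on the amide-type nitrogen in the ring proves far more consequential in this assay than the group on the other nitrogen: hydrogen in its place gives a 660-fold higher number from compound 2 to compound 3 (2.82 log units; beyond the scatter), whereas isopropyl in place of cyclohexyl gave no change at the digits printed from compound 1 to compound 2 (within the scatter). The loss of this one heavy atom thus separates a strong inhibitor from a much weaker one on the shared core, a sensitivity that the flat earlier step gave no sign of. Nothing measured here accounts for the size of this loss.

The compounds shown leave open whether this nitrogen needs methyl specifically or would accept an ethyl group or a longer chain. They also leave open whether hydrogen at this position would cost as much with cyclohexyl in place of isopropyl.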